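The compounds below may be only part of what the source reports. "The series", "measured", "known", "first", "only" and "open" are said of these compounds alone.

Measured so far in a physicochemical assay for solubility, with a stated time of 24 h, tested at 30 mg/mL; on this read-out lower numbers stand for lower solubility and higher numbers for higher solubility
- compound 1 `CC(=O)N1CC(CC(=O)NO)(NS(=O)(=O)c2ccc(OCc3cc(C)nc4ccccc34)cc2)C1` gives 800000 nM
- compound 2 `CC(=O)N1CC(CC(=O)NO)(NS(=O)(=O)c2ccc(OCc3cc(C)nc4ccccc34)cc2C)C1` gives 900000 nM
- compound 3 `CC(=O)N1CC(CC(=O)NO)(NS(=O)(=O)c2ccc(OCc3cc(C)nc4ccccc34)c(C)c2)C1` gives 400000 nM

Compound 1 holds the middle of these three numbers, but it is not separated from either of the others, as both of its steps lie within the scatter (a 1.1-fold higher number from compound 1 to compound 2 (0.05 log units; within the scatter) and a 2.0-fold lower number from compound 1 to compound 3 (0.30 log units; within the scatter)).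

The next compound to be read is compound 4 `CCc1cc(COc2ccc(S(=O)(=O)NC3(CC(=O)NO)CN(C(C)=O)C3)cc2)c2ccccc2n1`. Its difference from compound 1 is methyl in place of hydrogen on a saturated chain carbon bound to an aromatic carbon, which turns 2-methylquinolin-4-yl into 2-ethylquinolin-4-yl.

Within the data shown here, no measured step makes this exact change. The closest evidence is the two steps above, each of which places methyl on an aromatic carbon rather than on a chain carbon, so they bear on it only indirectly. Neither step goes beyond the scatter, and they point in opposite directions, so they give little basis for predicting a direction. For this assay, no shift beyond the scatter is expected, with a slight lean towards a lower number resting only on the step to compound 3 (a 2.0-fold lower number from compound 1 to compound 3 (0.30 log units; within the scatter)).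

The estimated step is small and stays within the scatter (a 1.2-fold lower number from compound 1 to compound 4 (0.09 log units; within the scatter)).

For compound 4 the expected value is 650000 nM, with an estimated range from 300000 nM to 1300000 nM.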

Compound 4, solubility: 400000 nM
Compound 4: the middle estimate sits 1.6-fold (0.21 log units) above what was measured, within the range that was stated.
By their numbers in this assay, from the lowest: compounds 3, 4, 1 and 2 (each within the scatter of the next, the first and the last beyond it).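

In this assay, the position carrying the 2-methylquinolin-4-yl group now has a reading of its own: methyl in place of hydrogen on a saturated chain carbon bound to an aromatic carbon, which turns methyl to ethyl, gives a 2.0-fold lower number from compound 1 to compound 4 (0.30 log units; within the scatter). Among these compounds, compounds 2 and 3 carried their added methyl on an aromatic carbon, so this is the first step at this chain carbon, and like those two steps it does not leave the scatter, which means 2-ethylquinolin-4-yl cannot be separated from 2-methylquinolin-4-yl on this read-out. Nothing available on the series accounts for the size or direction of this step, so it stands as an observation without an explanation.

Still open, from the compounds shown here alone, is whether a longer chain such as propyl, or a polar group such as an amine or a carboxylic acid, at this same place would move the number beyond the scatter. Also open, going by these compounds, is whether the methyl to ethyl step would read the same on the core of compound 2 or compound 3, since this single step rests on the core of compound 1 alone.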